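The source may hold more compounds than are shown below. What is called first, only, known or untested is meant among the compounds shown, and "the series" means these compounds.

In a functional assay on A549 cells (Homo sapiens) for cytotoxicity, read by MTT assay, with a stated time of 24 h (a lower number here means a stronger inhibitor, a higher number a weaker inhibitor), compound 3 (`O=c1nc2ccc(Br)cn2cc1Cc1ccccc1`) gives only a limit, > 1000000 nM. Compound 1 (`COc1ccc(Cc2cn3cc(Br)ccc3nc2=O)cc1`) also gives only a limit, > 1000000 nM. For the measured compounds named here, the one measured step, a step that the two limits leave unreadable from compound 1 to compound 3, therefore offers no size to carry forward, and compound 3 stands at the limit of > 1000000 nM in this assay, at which 2 of the 3 values shown sit. Compound 4 (`Nc1cc(Br)cn2cc(Cc3ccccc3)c(=O)nc12`) has amino in place of hydrogen on an aromatic carbon of compound 3: amino in place of hydrogen on an aromatic carbon. Going by the values given here, the only guide is compound 2 (`Nc1cccn2cc(Cc3ccccc3)c(=O)nc12`), which carries the amino group without the bromo group and gives 98000 nM in this assay, so a move toward stronger inhibition is expected. The expected change is an at least 10-fold lower number from compound 3 to compound 4 (1.00 log units; beyond the scatter). For compound 4 the estimated value is 100000 nM, with an expected range of 25000 nM to 600000 nM.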

Compound 4, half-maximal inhibitory concentration: > 1000000 nM
Compound 4: no number, only a limit (the forecaster's own chance of this, stated with the estimate: 25%); at least 10-fold (1.00 log units) between middle value and limit.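

With the amino group on this aromatic carbon, the bromo group makes a clear difference in this assay: bromo in place of hydrogen gives an at least 10-fold higher number from compound 2 to compound 4 (1.00 log units; beyond the scatter). Going by these compounds, the steps joining two limits cannot be read, so the amino group's own effect with the bromo group present stays unknown. All three compounds carrying the bromo group sit together at one limit: the limit of > 1000000 nM in this assay, at which 3 of the 4 values shown sit.

On these data alone, whether a chloro or methyl group in place of the bromo group would also reach this limit remains open. So does the reading of a methylamino group in place of the amino group.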